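A few compounds are considered here, and "the series" means these few. Any claim that something is new, unique, unknown or untested is made for them only; others in the source may bear on it.

Compound 3 `COc1ccccc1CN(C)CCCCn1c(=O)oc2ccccc21` stands as the highest of the three numbers measured in an assay on membranes from liver for displacement of a labelled ligand from Sigma non-opioid intracellular receptor 1 (Rattus norvegicus), read by scintillation counting; on this read-out higher numbers stand for weaker inhibition and lower numbers for stronger inhibition: compound 3 gives 594 nM, whereas compound 1 `CN(CCCCn1c(=O)oc2ccccc21)Cc1ccc(Cl)cc1` gives 7.1 nM and compound 2 `CN(CCCCn1c(=O)oc2ccccc21)Cc1ccccc1` gives 2.6 nM. Compound 4 `Cc1ccc(CN(C)CCCCn2c(=O)oc3ccccc32)cc1` differs from compound 3 in one place: 4-methylphenyl in place of 2-methoxyphenyl on a saturated chain carbon bound to an amine nitrogen. Going by the values given here, two measured steps bear on this change. The step of an 84-fold higher number from compound 1 to compound 3 (1.92 log units; beyond the scatter) shows what followed when 2-methoxyphenyl entered in place of 4-chlorophenyl, and the step of a 230-fold higher number from compound 2 to compound 3 (2.36 log units; beyond the scatter) shows what followed when methoxy entered in place of hydrogen on an aromatic carbon. Both were large and both raised the number, so removing the 2-methoxyphenyl is expected to undo most of that rise. Among the compounds with values here, the entering 4-methylphenyl has no measured counterpart here, but the step of a 2.7-fold lower number from compound 1 to compound 2 (0.44 log units; beyond the scatter) shows that exchanging a group on an aromatic carbon moved the number only modestly. Compound 4 is therefore expected to show a step of a 130-fold lower number from compound 3 to compound 4 (2.12 log units; beyond the scatter) in this assay. The estimate for compound 4 in this assay is 4.5 nM, with a range from 1.5 nM to 15 nM.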

Compound 4, inhibition constant: 97 nM
For compound 4 the middle estimate is 22-fold (1.33 log units) below the measured one, and the stated range ends below it.
By their numbers in this assay, from the lowest: compound 2; then compound 1; then compound 4; then compound 3.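

In this assay, the step of a 6.1-fold lower number from compound 3 to compound 4 (0.79 log units; beyond the scatter) shows that losing the 2-methoxyphenyl does not by itself bring the number back to the level of the two earlier compounds. The group entering here matters in its own right: a 37-fold higher number from compound 2 to compound 4 (1.57 log units; beyond the scatter) with methyl in place of hydrogen and a 14-fold higher number from compound 1 to compound 4 (1.14 log units; beyond the scatter) with methyl in place of chloro, so this exchange on an aromatic carbon is large, whereas a 2.7-fold lower number from compound 1 to compound 2 (0.44 log units; beyond the scatter) was modest. Nothing measured here explains why methyl and chloro part so widely at this position.

The compounds shown leave open whether this rise belongs to methyl alone or would also follow an ethyl or a fluoro in its place. They also leave open how a methoxy would behave if it replaced the methyl of the 4-methylphenyl.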